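Swapping the Six-Membered Ring of Compound 2: Clearance Outlook

The source may hold more compounds than are shown below. What is called first, only, known or untested is meant among the compounds shown, and "the series" means these compounds.

Measured compounds:
compound 1, `Cc1nn(CC(=O)N2CCN(c3sc(C(F)(F)F)nc3-c3nc4ccccc4[nH]3)C[C@H]2C)cc1CN(C)C`, with 37 mL.min-1.g-1
compound 2, `Cc1nc(C)n(CC(=O)N2CCN(c3sc(C(F)(F)F)nc3-c3nc4ccc(C5CCOCC5)cc4[nH]3)C[C@H]2C)n1`, with 18 mL.min-1.g-1

Of the compounds shown here, two have been tested in an ADME assay on microsomes from liver (Homo sapiens) for metabolic stability, read by LC-MS, using NADPH, with a stated time of 15 min, tested at 1 uM; a higher number here means faster removal of the compound, a lower number slower removal. In this assay compound 1 gives 37 mL.min-1.g-1, and compound 2 gives 18 mL.min-1.g-1. Compound 2 therefore stands at the lower of the two numbers, and the gap to compound 1 lies beyond the usual scatter of the measurement. The two structures differ in more than one place, so the difference between them cannot be tied to a single group.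

The next compound, compound 3, `Cc1nc(C)n(CC(=O)N2CCN(c3sc(C(F)(F)F)nc3-c3nc4ccc(C5CCN(C)CC5)cc4[nH]3)C[C@H]2C)n1`, changes compound 2 in one place: 1-methylpiperidin-4-yl in place of oxan-4-yl on an aromatic carbon. For the measured compounds named here, no pair of measured compounds shows this particular exchange, so there is no measured step from which to read its effect. With nothing in the two measured values pointing either way, compound 3 is expected to land close to compound 2, with a step of a 1.2-fold higher number from compound 2 to compound 3 (0.09 log units; within the scatter) that stays within the scatter. Compound 3 is estimated at 22 mL.min-1.g-1 in this assay, with a range from 10 mL.min-1.g-1 to 45 mL.min-1.g-1.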

Compound 3, intrinsic clearance in microsomes: 27 mL.min-1.g-1
Beside the measured number, compound 3's estimate is 1.2-fold (0.09 log units) below it, and the stated range covers the measured number.
By their numbers in this assay, from the lowest: compounds 2, 3 and 1 (each within the scatter of the next, the first and the last beyond it).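

For the compounds shown here, the exchange of oxan-4-yl for 1-methylpiperidin-4-yl on an aromatic carbon gives, in this assay, a 1.5-fold higher number from compound 2 to compound 3 (0.18 log units; within the scatter) and is the first change here that can be read in one place, as compound 1 and compound 2 differ in more than one. At this position, the six-membered non-aromatic ring can therefore carry either its oxygen or its methyl-bearing nitrogen without a difference that this measurement can separate from its usual scatter. Nothing among the data shown bears on what lies behind this result.

The compounds shown leave open how a piperidine ring without the methyl, a morpholine ring or an open-chain amine would read at this same position, so one exchange cannot yet define what the position accepts. They also leave open how the gap between compound 1 and compound 2 divides among the places in which those two structures differ, and no single-place pair shown yet separates these contributions.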